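This account rests on a few compounds, and the source may have more. Where it says the series, first, only, none or still open, it means among the compounds named here.

This account follows the step from compound 3 to compound 4 in an assay on HEK293 cells for activation of Kir3.1/Kir3.2 (Homo sapiens), read by thallium flux; on this read-out lower numbers stand for an effect already at smaller amounts and higher numbers for an effect only at larger amounts of compound. Among the compounds with values here, compound 3, `Cc1cc(NC(=O)Cn2nnc(-c3cccnc3)n2)n(C2CCCCC2)n1`, gives 1930 nM, the only value in this assay that is reported as a number. Compound 1, `Cc1cc(NC(=O)Cn2nnc(-c3ccccc3)n2)n(C2CCC(C)(C)CC2)n1`, returns only a limit, > 221 nM. Compound 2, `CC1(c2cc(NC(=O)Cn3nnc(-c4ccccc4)n3)n(C3CCCCC3)n2)CC1`, likewise returns only a limit, > 10000 nM. Within the data shown here, no two of the measured compounds differ in one place alone, so no measured step is available, and the two limits, the limit of > 10000 nM in this assay, at which 1 of the 3 values shown sits, and (the limit of > 221 nM in this assay, at which 1 of the 3 values shown sits), offer no number to set against compound 3. Compound 4, `Cc1cc(NC(=O)Cn2nnc(-c3cccc(F)n3)n2)n(C2CCCCC2)n1`, is the compound not yet measured. It differs from compound 3 in one place: 6-fluoropyridin-2-yl in place of pyridin-3-yl on an aromatic carbon. Among the measured compounds shown here, with no measured step to lean on, this change is expected to shift the half-maximal effective concentration only modestly, in either direction, and perhaps not beyond the scatter. The step of a 1.3-fold higher number from compound 3 to compound 4 (0.11 log units; within the scatter) is therefore expected to be small. Compound 4 is estimated at 2500 nM in this assay, within a range from 600 nM to 10000 nM, and a result reported only as a limit cannot be ruled out.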

Compound 4, half-maximal effective concentration: > 3000 nM
Compound 4 was reported as a limit (the forecaster's own chance of this, stated with the estimate: 30%); middle value at least 1.2-fold (0.07 log units) from the limit.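

In this assay, within the data shown here, the exchange of pyridin-3-yl for 6-fluoropyridin-2-yl on an aromatic carbon of the five-membered ring gives the first step between compounds that differ in one place: an at least 1.5-fold higher number from compound 3 to compound 4 (0.19 log units; that floor lies within the scatter). This step shows that the exchange brings no lower number at this position, although its printed floor does not establish a rise beyond the scatter. How far the number rises stays unknown, and compound 4 is recorded only as a limit of the assay: the limit of > 3000 nM in this assay, at which 1 of the 4 values shown sits.

The exchange moves the ring nitrogen and adds the fluorine in one step, so the compounds shown cannot separate the two. Also open, on these data alone, is how a pyridin-2-yl without fluorine, or a pyridine ring bearing a methoxy group or an amine, would read out at this position.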